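Biaryl tail swap and predicted cytotoxicity of compound 3

The source may report more compounds than this note shows. Statements on the series, on what has been measured and on what is new or still open speak of the compounds shown alone.

Compound 1: `Cc1c(Cc2ccc(C(F)(F)F)cc2)c(=O)oc2cc(OCC(O)CN3CCC(C(N)=O)CC3)ccc12`, 89300 nM
Compound 2: `Cc1c(Cc2ccc(-c3ccc(Cl)cc3)cc2)c(=O)oc2cc(OCC(O)CN3CCC(C(N)=O)CC3)ccc12`, 32900 nM

In an ADME assay on A549 cells (Homo sapiens) for cytotoxicity, read by CellTiter-Glo (on this read-out higher numbers stand for lower toxicity in this test and lower numbers for higher toxicity in this test), compound 2 gives the lower of the two numbers, with compound 1 the nearest neighbour at a higher value. Compound 3, `Cc1c(Cc2ccc(-c3ccccc3C#N)cc2)c(=O)oc2cc(OCC(O)CN3CCC(C(N)=O)CC3)ccc12`, differs from compound 2 in one place: 2-cyanophenyl in place of 4-chlorophenyl on an aromatic carbon. Among the measured compounds shown here, only one measured step bears on this position: a 2.7-fold lower number from compound 1 to compound 2 (0.43 log units; beyond the scatter), where a biaryl tail replaced a small single group. For the measured compounds named here, the move from compound 2 to compound 3 keeps the biaryl tail and alters only its outer ring, so that step is a weaker guide than it might seem; no measured pair shows a chloro group traded for a nitrile. The expected step is therefore small, a 1.2-fold higher number from compound 2 to compound 3 (0.08 log units; within the scatter), within the usual scatter. For compound 3 the estimated value is 40000 nM, with a plausible range from 15000 nM to 100000 nM.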

Compound 3, half-maximal cytotoxic concentration: 33200 nM
Compound 3: the middle estimate sits 1.2-fold (0.08 log units) above what was measured; the range from low to high includes it.
By their numbers in this assay, from the lowest: compounds 2 and 3 (each within the scatter of the next); then compound 1.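

In this assay, the exchange of 4-chlorophenyl for 2-cyanophenyl on the outer ring of the biaryl tail gives no step beyond the scatter (a 1.0-fold higher number from compound 2 to compound 3 (0.00 log units; within the scatter)), so at this position, a nitrile-bearing ring and a chlorine-bearing ring read alike. The second comparison (a 2.7-fold lower number from compound 1 to compound 3 (0.43 log units; beyond the scatter)) matches in size the earlier step (a 2.7-fold lower number from compound 1 to compound 2 (0.43 log units; beyond the scatter)), so two different biaryl tails now stand apart from the trifluoromethyl group. Nothing measured here offers a reason for either result.

On these data alone, it remains open whether the number would hold with an amine or a carboxylic acid on that outer ring. As far as these compounds go, all three compounds also share the rest of their structure, so it is equally open whether the tail would behave this way on a different core.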